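This account rests on a few compounds, and the source may have more. Where it says the series, first, only, none or still open, it means among the compounds named here.

Measured compounds and their values:

- compound 1 `COC(=O)c1cc(-c2cccc(NC(=O)c3ccc(/C=C/C(=O)c4ccccc4)cc3)c2)on1` — in an ADME assay on Vero cells (Chlorocebus sabaeus) for cytotoxicity, read by MTT assay, with a stated time of 72 h (on this read-out higher numbers stand for lower toxicity in this test and lower numbers for higher toxicity in this test), compound 1 gives > 50 ug/mL, a limit of the assay rather than a number.
- compound 2 `COC(=O)c1cc(-c2cccc(NC(=O)c3ccc(/C=C/C(=O)c4cccc(OC)c4)cc3)c2)on1` — in this assay compound 2 gives > 100 ug/mL, again a limit of the assay.
- compound 3 `COC(=O)c1cc(-c2cccc(NC(=O)c3ccc(/C=C/C(=O)c4ccccc4O)cc3)c2)on1` — in this assay compound 3 gives "not determined" (no result reported), so no result exists for it.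
- compound 4 `COC(=O)c1cc(-c2cccc(NC(=O)c3ccc(/C=C/C(=O)c4cccc(Br)c4)cc3)c2)on1` — not yet measured.

Compound 3 therefore stands nowhere on the numbers: it has no value in this assay, and the two values that exist for its neighbours are both limits, one at the limit of > 100 ug/mL in this assay, at which 1 of the 3 values shown sits, and one at the limit of > 50 ug/mL in this assay, at which 1 of the 3 values shown sits. Within the data shown here, the only step between measured compounds, a step that the two limits leave unreadable from compound 1 to compound 2, cannot be read, since both ends are limits.

The change from compound 3 to compound 4 is 3-bromophenyl in place of 2-hydroxyphenyl on a carbonyl carbon. Among the measured compounds shown here, no measured step bears on this exchange of one aromatic ring for another on the carbonyl carbon, so no size or direction can be drawn from the data beyond noting that both measured compounds sit at limits of the assay.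

On that basis compound 4 is expected to give 80 ug/mL in this assay, with a range from 30 ug/mL to 200 ug/mL, and most likely to be reported as a limit as well.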

Compound 4, half-maximal cytotoxic concentration: > 100 ug/mL
Compound 4: a limit, no number (the forecaster's own chance of this, stated with the estimate: 70%); at least 1.2-fold (0.09 log units) between middle value and limit.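

In this assay compound 4 gives > 100 ug/mL, a limit of the assay and not a number. Compound 1 and compound 2 also carry limits, so the steps from each of them to compound 4 cannot be read. The compounds shown leave open how these three truly compare and where compound 3 stands.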